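The source may hold more compounds than are shown below. What is called first, only, known or untested is meant among the compounds shown, and "the series" means these compounds.

Of the compounds shown here, three that share one core have been measured in a functional assay on the whole organism for inhibition, with Rattus norvegicus as the target, read by paw edema, with stated times of 30 min and 5 h, at a dose of 0.28 mmol/kg by the oral route; on this read-out higher numbers stand for more inhibition at the one dose given (going by the name of the read-out) and lower numbers for less inhibition. Compound 1 `COc1ccc(-n2nc(C(=O)Nc3ccccc3OC)nc2-c2cc(OC)c(OC)c(OC)c2)cc1` gives 10%. Compound 2 `COc1ccc(-n2nc(C(=O)Nc3ccc(C)cc3)nc2-c2cc(OC)c(OC)c(OC)c2)cc1` gives 42%, and compound 3 `COc1ccc(-n2nc(C(=O)Nc3cccc(F)c3)nc2-c2cc(OC)c(OC)c(OC)c2)cc1` gives 53%. Compound 3 stands highest of the three numbers, with compound 2 nearest and compound 1 furthest away.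

Compound 4 `COc1ccc(-n2nc(C(=O)Nc3ccccc3)nc2-c2cc(OC)c(OC)c(OC)c2)cc1` has not yet been measured in this assay. It differs from compound 3 in a single place: hydrogen in place of fluoro on an aromatic carbon. Going by the values given here, no measured pair shows this exact change, so the expectation has to lean on the steps that end at compound 3. There, a number 43 percentage points higher from compound 1 to compound 3 (beyond the scatter) was a large step beyond the scatter, and a number 11 percentage points higher from compound 2 to compound 3 (beyond the scatter) was a modest step beyond the scatter. Both steps swapped the whole group on the amide-type nitrogen, whereas here only the fluoro is taken away and nothing but hydrogen enters. Since the smaller swap gave the smaller step, the loss of the fluoro is expected to cost some inhibition, but not to return compound 4 to the level of compound 1.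

Compound 4 is therefore estimated at 40%, within a range from 25% to 55%. This estimate amounts to a number 13 percentage points lower from compound 3 to compound 4 (beyond the scatter), expected to be a downward step of modest size.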

Compound 4, a percentage reported as inhibition, in the whole organism at one dose (the size of the read-out at that dose, not a potency): 46%
For compound 4 the middle estimate is 6 percentage points below the measured one; the range from low to high includes it.
By their numbers in this assay, from the lowest: compound 1; then compounds 2, 4 and 3 (each within the scatter of the next, the first and the last beyond it).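

In this assay, taking the fluoro away from the 3-fluorophenyl group gives a number 7 percentage points lower from compound 3 to compound 4 (within the scatter), so at this one dose the plain phenyl amide cannot be told apart from its fluoro analogue, and the fluoro on this aromatic carbon is not required for the inhibition seen. Replacing the methyl of the 4-methylphenyl group with hydrogen gives a number 4 percentage points higher from compound 2 to compound 4 (within the scatter), so neither the fluoro nor the methyl shows a gain over hydrogen, even though compound 2 and compound 3 themselves lie a modest step apart. By contrast, removing the methoxy gives a number 36 percentage points higher from compound 1 to compound 4 (beyond the scatter), which ties the low number of compound 1 to its 2-methoxyphenyl group, the only one of the four amide groups that stands apart from the plain phenyl. No data on any property of these groups bear on this result.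

The compounds shown leave open whether the low number follows the methoxy group itself or the place it occupies, since methoxy appears at only one place on this ring. They also leave open how an amine, a carboxylic acid or a longer chain such as butoxy on this phenyl ring would fare.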